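The compounds below may be only part of what the source reports. "The series", "measured", "known", "first", "only" and "open" are said of these compounds alone.

Among the compounds with values here, compound 1 `CC(C)(C)OC(=O)N1CCC(CN(Cc2ccc(Cl)cc2)Cc2ccc([N+](=O)[O-])s2)C1` is the one member of this set with a number: in a functional assay on HEK293 cells for agonist activity at nuclear receptor subfamily 1 group D member 1 (Homo sapiens), read by a luciferase reporter, with a stated time of 24 h (on this read-out lower numbers stand for an effect already at smaller amounts and higher numbers for an effect only at larger amounts of compound), compound 1 gives 1800 nM. Compound 2 `O=[N+]([O-])c1ccc(CN(Cc2ccc(Cl)cc2)CC2CCN(Cc3ccccc3)C2)s1` carries no result in this assay: for compound 2 the entry reads "not determined" (no result reported). Compound 3 `O=C(Oc1ccccc1)N1CCC(CN(Cc2ccc(Cl)cc2)Cc2ccc([N+](=O)[O-])s2)C1` is likewise without a result in this assay: for compound 3 the entry reads "not determined" (no result reported), so compound 3 stands on no number at all. Compound 4 `O=C(Nc1ccccc1)N1CCC(CN(Cc2ccc(Cl)cc2)Cc2ccc([N+](=O)[O-])s2)C1` has yet to be tested in this assay. It differs from compound 3 in one place: anilino in place of phenoxy on a carbonyl carbon. Within the data shown here, no step between two measured compounds is known, so nothing in hand shows how this change moves the read-out; the step is expected to stay within the scatter of this assay, in no set direction. Guided only by compound 1 at 1800 nM, compound 4 is expected to give about 1500 nM in this assay, within 300 nM to 8000 nM.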

Compound 4, half-maximal effective concentration: 620 nM
For compound 4 the middle estimate is 2.4-fold (0.38 log units) above the measured one; measured number inside the range.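

In this assay, the group on a carbonyl carbon whose other neighbour is an amide-type nitrogen in a ring now has a measured effect: anilino in place of tert-butoxy gives a 2.9-fold lower number from compound 1 to compound 4 (0.46 log units; beyond the scatter). The change from phenoxy to anilino cannot be read, as compound 3 has no number. No measurement given here explains the step.

The step exchanges both the oxygen for nitrogen and the tert-butyl for phenyl, and the compounds shown do not separate the two. On these data alone, a tert-butylamino or benzylamino group at this place remains open.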